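The compounds below may be only part of what the source reports. "The series", "measured", "known", "first", "only" and "open" are said of these compounds alone.

Working notes on the series. Compound 1 `COc1cc(Oc2ccccc2NC(C)=C2C(=O)CC(c3ccccc3)CC2=O)ccc1N` is the reference point: in a functional assay on HMEC-1 cells (Homo sapiens) for antiproliferative activity, read by cell counting, with a stated time of 4 days (a lower number here means a stronger inhibitor, a higher number a weaker inhibitor), compound 1 gives 29 nM. Compound 2 `CC(Nc1ccccc1Oc1cccc(F)c1)=C1C(=O)CC(c2ccccc2)CC1=O` gives 360 nM, and compound 3 `CC(Nc1ccccc1Oc1ccc(C(C)O)cc1)=C1C(=O)CC(c2ccccc2)CC1=O` gives 140 nM. Compound 3 thus stands second highest of the three numbers, nearest to compound 2 and furthest from compound 1. All three measured steps alter the group on the oxygen on the aromatic ring: a 12-fold higher number from compound 1 to compound 2 (1.09 log units; beyond the scatter), a 4.8-fold higher number from compound 1 to compound 3 (0.68 log units; beyond the scatter) and a 2.6-fold lower number from compound 2 to compound 3 (0.41 log units; beyond the scatter).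

Compound 4 `CCOc1ccccc1NC(C)=C1C(=O)CC(c2ccccc2)CC1=O` is not yet measured. It differs from compound 3 in one place: ethyl in place of 4-(1-hydroxyethyl)phenyl on an oxygen on an aromatic ring. Each measured step exchanges one six-membered aromatic ring for another at that oxygen, with shifts from modest to large; none removes the ring altogether, so the size of the present change has no direct anchor. What the steps do show is that moving away from the substituent of compound 1 raises the number, and that two different rings at the oxygen differ only modestly, as in a 2.6-fold lower number from compound 2 to compound 3 (0.41 log units; beyond the scatter).

For compound 4 a step beyond the scatter toward a higher number is expected, a 4.3-fold higher number from compound 3 to compound 4 (0.63 log units; beyond the scatter). Compound 4 is therefore estimated at 600 nM, with a range from 200 nM to 2500 nM.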

Compound 4, half-maximal inhibitory concentration: 100 nM
Compound 4: the middle estimate sits 6.0-fold (0.78 log units) above what was measured; measured number outside the range, below it.
By their numbers in this assay, from the lowest: compound 1; then compounds 4 and 3 (each within the scatter of the next); then compound 2.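

In this assay the aromatic ring on the oxygen can be lost without a readable change from compound 3: with ethyl in place of 4-(1-hydroxyethyl)phenyl (a 1.4-fold lower number from compound 3 to compound 4 (0.15 log units; within the scatter)) the step stays within the scatter, although ethyl has no ring, no hydrogen-bond donor and no hydrogen-bond acceptor. The same exchange against the other two rings runs in opposite directions (a 3.6-fold lower number from compound 2 to compound 4 (0.56 log units; beyond the scatter); a 3.4-fold higher number from compound 1 to compound 4 (0.54 log units; beyond the scatter)). Among these four compounds, a ring at this oxygen therefore gives a lower number than ethyl only in compound 1, a higher number in compound 2 and no readable difference in compound 3, so the effect of the ring depends on what it carries.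

Still open, on these data alone, is whether a shorter or longer chain, such as methyl or propyl, or an amine at the end of the ethyl group, would keep the number where ethyl puts it, and whether the amino group or the methoxy group of 4-amino-3-methoxyphenyl accounts for the lower number of compound 1. Nothing at hand explains this order among the groups.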